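The compounds below may be only part of what the source reports. "The series", "measured", "known", "first", "only" and "open" are said of these compounds alone.

The measured compounds:

Compound 1, `COc1cccc(C2CCc3nc[nH]c3C2)c1`, in a functional assay on CHO cells for agonist activity at Alpha-1B adrenergic receptor (Homo sapiens), read by FLIPR and calcium flux (a higher number here means that more compound is needed for the effect, a lower number that less compound is needed), gives > 10000 nM, which is a limit of the assay and not a number.
Compound 2, `Clc1ccccc1C1CCc2nc[nH]c2C1`, in this assay gives > 10000 nM, again a limit rather than a number.
Compound 3, `Clc1cccc(C2CCc3nc[nH]c3C2)c1`, in this assay gives > 10000 nM, also a limit.

Within the data shown here, all three values therefore sit at the same point, (the limit of > 10000 nM in this assay, at which 3 of the 3 values shown sit), and no compound can be ranked against another. The change from compound 3 to compound 1 is methoxy in place of chloro on an aromatic carbon. Its size is a step that the two limits leave unreadable from compound 3 to compound 1, because both ends rest on (the limit of > 10000 nM in this assay, at which 3 of the 3 values shown sit). Compound 2 and compound 3 are built from the same atoms joined differently; the difference between their cores is not broken down here.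

The unmeasured compound 4, `COc1ccccc1C1CCc2nc[nH]c2C1`, arises from compound 2 by methoxy in place of chloro on an aromatic carbon. Set against the step from compound 3 to compound 1, the two place lines are not the same word for word: in one the methoxy sits meta to a group of 9 heavy atoms, in the other ortho to a group of 9 heavy atoms, so this is the same kind of change, not the same change. Because compound 2 sits at > 10000 nM and the related step is a step that the two limits leave unreadable from compound 3 to compound 1, the expected step from compound 2 to compound 4 is a step that the limit leaves unreadable from compound 2 to compound 4, with the caution that the earlier step could not be read. Compound 4 is estimated at 20000 nM, between 5000 nM and 100000 nM, and most likely the assay will again report only a limit.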

Compound 4, half-maximal effective concentration: > 10000 nM
Compound 4: no number, only a limit; the forecaster's own chance of this, stated with the estimate: 85%; the middle value is on the limit's open side.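

In this assay compound 4 gives > 10000 nM as a limit of the assay and not a number. No step can be read from compound 2 to compound 4, since both ends of this change rest on the same limit: the limit of > 10000 nM in this assay, at which 4 of the 4 values shown sit.

In this assay the compounds shown leave open whether methoxy in place of chloro, or the place of either group on the aromatic ring, changes the effect at all.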